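A few compounds are considered here, and "the series" means these few. Any claim that something is new, unique, unknown or untested is made for them only; others in the source may bear on it.

Three compounds sharing one core have been followed in an ADME assay on the whole organism (strain CD-1) for metabolic stability, with Mus musculus as the target, at a dose of 50 mg/kg by the oral route; a higher number here means that the compound lasts longer, a lower number that the compound disappears faster. Compound 1 (`O=C(N[C@@H]1C[C@@H](C(=O)NC[C@@H]2CC(Br)=NO2)N(C(=O)OCc2cnc3ccccc3c2)C1)c1ccc(O)cc1`) gives 0.25 h, compound 2 (`O=C(NC[C@@H]1CC(Br)=NO1)[C@@H]1CCCN1C(=O)OCc1cnc2ccccc2c1`) gives 0.25 h, and compound 3 (`O=C(NC[C@@H]1CC(Br)=NO1)[C@@H]1C[C@@H](O)CN1C(=O)OCc1cnc2ccccc2c1`) gives 0.25 h. Compound 2 therefore stands level with both of the others.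

The next compound is compound 4 (`O=C(NC[C@@H]1CC(Br)=NO1)[C@@H]1C[C@@H](c2ccccc2)CN1C(=O)OCc1cnc2ccccc2c1`), and the change is phenyl in place of hydrogen on a saturated ring carbon, two ring bonds from the ring nitrogen. Within the data shown here, three measured steps bear on this, all at that same ring carbon. Hydrogen in place of ((4-hydroxyphenyl)carbonyl)amino gives no change at the digits printed from compound 1 to compound 2 (within the scatter). Hydroxy in place of ((4-hydroxyphenyl)carbonyl)amino gives no change at the digits printed from compound 1 to compound 3 (within the scatter). Hydroxy in place of hydrogen gives no change at the digits printed from compound 2 to compound 3 (within the scatter). None of these steps leaves the scatter, whichever of the three groups is exchanged. Phenyl itself has not been measured at this carbon, so the read-across is indirect. No movement in either direction beyond the scatter is expected in this assay, and the expected step is no change at the digits printed from compound 2 to compound 4 (within the scatter). For compound 4 the estimated half-life is 0.25 h, with an expected range of 0.15 h to 0.6 h.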

Compound 4, half-life: 0.25 h
Estimate against measurement, compound 4: no gap at the digits printed; measured number inside the range.
By their numbers in this assay, from the lowest: compounds 1, 2, 3 and 4 (each within the scatter of the next).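

In this assay, phenyl on this saturated ring carbon gives no change at the digits printed from compound 2 to compound 4 (within the scatter) when it replaces hydrogen, no change at the digits printed from compound 3 to compound 4 (within the scatter) when it replaces hydroxy, and no change at the digits printed from compound 1 to compound 4 (within the scatter) when it replaces ((4-hydroxyphenyl)carbonyl)amino. The tolerated set at this carbon, two ring bonds from the ring nitrogen, therefore now includes a six-membered aromatic ring of carbon only attached directly to the ring carbon, alongside hydrogen, hydroxy and the larger amide-linked group, and none of the four separates from the others in this read-out. No measurement is available that explains why the half-life stays level across these groups.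

Going by these compounds, whether an amine, a carboxylic acid or a longer chain on this same ring carbon would take the half-life beyond the scatter remains open. Also open, on these data alone, is whether a change elsewhere on the shared core, such as replacing the bromine with chlorine or a methoxy group, would shift the number when the group at this carbon is held constant.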